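Ring Swap at the Sulfur-Linked Chain: Compound 1 to 3

The source may report more compounds than this note shows. Statements on the series, on what has been measured and on what is new or still open speak of the compounds shown alone.

Two compounds of this series carry numbers in an assay on microsomes from liver for inhibition of sterol O-acyltransferase 1 (Rattus norvegicus); a higher number here means a weaker inhibitor, a lower number a stronger inhibitor. Compound 1 `CC1(C)CC(=O)OC(CSc2nc(-c3ccccc3)c(-c3ccccc3)[nH]2)C1` gives 100 nM, the lowest of the two values. Compound 2 `Clc1cccc(-c2[nH]c(SCC3CCCCO3)nc2-c2ccccc2)c1` gives 560 nM in this assay, a higher number than that of compound 1 by a gap beyond the scatter; the two differ in more than one place, so the comparison tells only what the two values show, not which change matters.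

Compound 3 `c1ccc(-c2nc(SCC3CCCCC3)[nH]c2-c2ccccc2)cc1` has not yet been measured in this assay. Relative to compound 1 the change is a group of 6 heavy atoms (6 carbon; one six-membered non-aromatic ring of carbon only) in place of a group of 9 heavy atoms (7 carbon, 2 oxygen; one six-membered non-aromatic ring with 1 hetero atom), on a saturated chain carbon bound to a sulfur. Within the data shown here, no pair of measured compounds differing in one place exists here, so the size of this kind of change has no precedent. The expected step of a 2.0-fold higher number from compound 1 to compound 3 (0.30 log units; within the scatter) is a modest rise in the number, possibly within the scatter, since compound 1 at 100 nM is the only anchor and the chain is kept while the ring changes. For compound 3 the estimate in this assay is 200 nM, with a range from 60 nM to 700 nM.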

Compound 3, half-maximal inhibitory concentration: 100 nM
Compound 3: the middle estimate sits 2.0-fold (0.30 log units) above what was measured, within the range that was stated.
By their numbers in this assay, from the lowest: compounds 1 and 3 (each within the scatter of the next); then compound 2.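

In this assay, the position on the saturated chain carbon bound to a sulfur now has its first comparison that differs in one place: cyclohexyl in place of the group of compound 1, a six-membered non-aromatic ring with 1 hetero atom, gives no change at the digits printed from compound 1 to compound 3 (within the scatter). On the core of compound 1, then, the 2 oxygen atoms, the 2 hydrogen-bond acceptors and the double bond outside aromatic rings of the group that leaves are not required for a value of this size, and a carbon-only ring serves equally well here. No measurement on hand bears on why the two groups read alike, so this equality remains an observation without an explanation.

The compounds shown leave open whether this position accepts an amine or a carboxylic acid on the ring, or a longer chain between the sulfur and the ring, as readily as it accepts cyclohexyl. They also leave open whether the same swap would read alike on the core of compound 2, since this single step comes from one core only.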